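This account rests on a few compounds, and the source may have more. Where it says the series, first, only, none or still open, it means among the compounds named here.

Measured so far in a physicochemical assay for lipophilicity, read by HPLC, measured as chromatographic lipophilicity, at pH 7.4; on this read-out higher numbers stand for higher lipophilicity and lower numbers for lower lipophilicity
- compound 1 `CC(C)(C)C(=O)N1CCNCC1c1ccccc1` gives 2.5
- compound 2 `CC(C)C(=O)N1N=CCC1c1ccccc1` gives 4.4

Compound 2 at 4.4 is the higher of the two, and its gap to compound 1 lies beyond the scatter. Compound 3 `CC(C)(CO)C(=O)N1N=CCC1c1ccccc1` differs from compound 2 by hydroxymethyl in place of hydrogen on a saturated chain carbon bound to a carbonyl carbon and two saturated chain carbons. Going by the values given here, no measured pair shows this change, so the expectation rests on the structural change alone. A fall beyond the scatter is expected in this assay with a number 0.80 log units lower from compound 2 to compound 3 (beyond the scatter) as the estimated step. For compound 3 the estimate is 3.6 with an expected range from 3.1 to 4.1 overall.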

Compound 3, distribution coefficient: 3.4
For compound 3 the middle estimate is 0.20 log units above the measured one, and the stated range covers the measured number.
By their numbers in this assay, from the lowest: compound 1; then compound 3; then compound 2.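

In this assay, hydroxymethyl in place of hydrogen on a saturated chain carbon bound to a carbonyl carbon and two saturated chain carbons gives a number 1.00 log units lower from compound 2 to compound 3 (beyond the scatter). Going by these compounds alone, this is the first single-place step, so this position does register a change in this read-out. No evidence available here accounts for the size of the step. The compounds shown leave open how a plain methyl, a methoxymethyl, an aminomethyl or a carboxylic acid at this carbon would compare with hydroxymethyl. They also leave open whether the step would be similar on another core.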